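The compounds below may be only part of what the source reports. "The series", "measured", "known", "first", "only" and "open" are said of these compounds alone.

Of the compounds shown here, two built on a shared core have been tested in an assay on HEK293 cells for inhibition of Steryl-sulfatase (Homo sapiens), tested at 0.1 uM; on this read-out higher numbers stand for a stronger effect at the one concentration tested and lower numbers for a weaker effect. Compound 1 `NS(=O)(=O)Oc1ccc2c(c1)CN(C(=O)c1cccc(N3CCC(N4CCCCC4)CC3)c1)CC2` gives 0%, the lower of the two numbers, while compound 2 `NS(=O)(=O)Oc1ccc2c(c1)CN(C(=O)c1ccc(N3CCN(Cc4ccccc4)CC3)cc1)CC2` gives 20.8%, a gap beyond the scatter. Compound 3 `NS(=O)(=O)Oc1ccc2c(c1)CN(C(=O)c1cccc(N3CCCCC3)c1)CC2` is compound 1 with one change: hydrogen in place of piperidin-1-yl on a saturated ring carbon. For the measured compounds named here, no measured pair shows what this change does, so the size of the step is uncertain. Because compound 1 gives 0% in this assay, the change is expected to leave the result near that level, with an expected step of a number 5 percentage points higher from compound 1 to compound 3 (within the scatter), not beyond the scatter. Compound 3 is estimated at 5%, ranging from 0% to 20%.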

Compound 3, a percentage reported as inhibition, at one concentration (the size of the read-out at that concentration, not a potency): 1%
Estimate against measurement, compound 3: 4 percentage points above, within the range that was stated.
By their numbers in this assay, from the lowest: compounds 1 and 3 (each within the scatter of the next); then compound 2.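

Replacing piperidin-1-yl with hydrogen on this saturated ring carbon gives a number 1 percentage points higher from compound 1 to compound 3 (within the scatter) in this assay. At this one concentration, the outer piperidin-1-yl ring therefore makes no measurable difference, though both compounds sit so close to zero that any loss from removing it could not be seen. No measurement available here offers an explanation for this result. As far as these compounds go, it remains open whether another group on this ring carbon, such as an amine, a carboxylic acid or a longer chain, would raise the read-out. From the compounds shown here alone, whether piperidin-1-yl matters in a compound with a clearly higher read-out also remains open.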